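Swapping the amide ring: pyridine to pyrazine

A few compounds are considered here, and "the series" means these few. Any claim that something is new, unique, unknown or untested is made for them only; others in the source may bear on it.

Compound 2: `COc1cc(F)c(NC(=O)c2ccccn2)cc1Nc1nccc(-c2cn(C)c3ccccc23)n1` gives 16500 nM
Compound 1: `COc1cc(F)c(NC(=O)c2ccnc(O)c2)cc1Nc1nccc(-c2cn(C)c3ccccc23)n1` gives 5920 nM

In a functional assay on NCI-H1975 cells (Homo sapiens) for antiproliferative activity, read by MTT assay, with a stated time of 72 h (on this read-out higher numbers stand for weaker inhibition and lower numbers for stronger inhibition), compound 2 stands at the highest of the two numbers measured, the weaker of the two. Going by the values given here, the only step measured so far, a 2.8-fold higher number from compound 1 to compound 2 (0.45 log units; beyond the scatter), changed the same ring on the carbonyl carbon. Compound 3 `COc1cc(F)c(NC(=O)c2cnccn2)cc1Nc1nccc(-c2cn(C)c3ccccc23)n1` differs from compound 2 by pyrazin-2-yl in place of pyridin-2-yl on a carbonyl carbon. Among the compounds with values here, no measured step covers this particular exchange, so the direction is uncertain. The estimate for compound 3 is 12000 nM, within 4000 nM to 36000 nM, a step of a 1.4-fold lower number from compound 2 to compound 3 (0.14 log units; within the scatter) that is expected to stay within the scatter.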

Compound 3, half-maximal inhibitory concentration: 24800 nM
Estimate against measurement, compound 3: 2.1-fold (0.32 log units) below, within the range that was stated.
By their numbers in this assay, from the lowest: compound 1; then compounds 2 and 3 (each within the scatter of the next).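

In this assay, pyrazin-2-yl and pyridin-2-yl on the carbonyl carbon cannot be told apart, with a 1.5-fold higher number from compound 2 to compound 3 (0.18 log units; within the scatter), so a second ring nitrogen brings no readable gain here. The step to 2-hydroxypyridin-4-yl is larger, with a 4.2-fold higher number from compound 1 to compound 3 (0.62 log units; beyond the scatter), and this keeps compound 1 ahead of compound 3. No measurement available here explains these differences. Compound 1 differs from the other two in both its hydroxy group and the ring's point of attachment, and these two changes remain unseparated. From the compounds shown here alone, whether an amine in place of that hydroxy group would keep the level of compound 1 also remains open.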